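Para-substituted ureas: from methylsulfanyl to acetyl

The source may report more compounds than this note shows. Statements on the series, on what has been measured and on what is new or still open speak of the compounds shown alone.

Measured so far in an ADME assay for permeability, using PAMPA, at pH 7.4; on this read-out higher numbers stand for higher permeability and lower numbers for lower permeability (apparent permeability)
- compound 1 `Cc1cc(NC(=O)Nc2ccc(Cl)c(Cl)c2)c2ccccc2n1` gives 197 10^-6 cm/s
- compound 2 `CSc1ccc(NC(=O)Nc2cc(C)nc3ccccc23)cc1` gives 473 10^-6 cm/s

Compound 2 holds the higher of the two values at 473 10^-6 cm/s and compound 1 sits lower at 197 10^-6 cm/s with a gap beyond the scatter. Among the measured compounds shown here, the two compounds are the only reference points so far.

The next entry is compound 3 `CC(=O)c1ccc(NC(=O)Nc2cc(C)nc3ccccc23)cc1` which differs from compound 2 by acetyl in place of methylsulfanyl on an aromatic carbon, para to a large group (acetyl in place of methylsulfanyl on an aromatic carbon). For the measured compounds named here, no measured step covers this change and the expectation therefore stays loose. A fall beyond the scatter is expected in this assay and the estimated step is a 2.5-fold lower number from compound 2 to compound 3 (0.40 log units; beyond the scatter) on this thin basis. For compound 3 the expected value is 190 10^-6 cm/s (estimated range 70 10^-6 cm/s to 480 10^-6 cm/s).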

Compound 3, apparent permeability: 473 10^-6 cm/s
Compound 3: middle estimate off by 2.5-fold (0.40 log units), on the low side; measured number inside the range.
By their numbers in this assay, from the lowest: compound 1; then compounds 2 and 3 (each within the scatter of the next).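

In this assay, acetyl in place of methylsulfanyl on an aromatic carbon, para to a large group, gives no change at the digits printed from compound 2 to compound 3 (within the scatter); compound 2 gives 473 10^-6 cm/s and compound 3 gives 473 10^-6 cm/s. Among the compounds shown here, this is the first step with a single place changed, and it shows that this read-out does not separate these two groups at this position, although the groups differ in their heavy atoms and acetyl brings a double bond outside the aromatic rings. No measured information is available to explain this result.

As far as these compounds go, whether the read-out stays level at this position with an amine, a carboxylic acid or a longer chain remains open. One step also leaves open whether the same exchange reads alike elsewhere on the ring.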